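Phenoxy to (ethoxycarbonyl)amino on the shared core

The source may report more compounds than this note shows. Statements on the series, on what has been measured and on what is new or still open speak of the compounds shown alone.

Three members of this set have been measured in an assay on isolated protein (strain Sprague-Dawley) for inhibition of Amine oxidase [flavin-containing] A (Rattus norvegicus), read by spectrophotometry, with a stated time of 5 min, tested at 10 uM; on this read-out lower numbers stand for less inhibition and higher numbers for more inhibition at the one concentration tested (going by the name of the read-out). Compound 1 `CCOC(=O)COc1cc(=O)oc2cc(OCc3cccc(Cl)c3)ccc12` gives 0%. Compound 2 `O=C(COc1cc(=O)oc2cc(OCc3cccc(Cl)c3)ccc12)N1CCCCC1`, piperidin-1-yl in place of ethoxy on a carbonyl carbon, gives 9%, a step of a number 9 percentage points higher from compound 1 to compound 2 (within the scatter). Compound 3 `O=c1cc(Oc2ccccc2)c2ccc(OCc3cccc(Cl)c3)cc2o1` gives 0%. Compound 3 stands level with compound 1, and the two together hold the lowest numbers of the three; the step is no change at the digits printed from compound 1 to compound 3 (within the scatter), and from the other side a number 9 percentage points lower from compound 2 to compound 3 (within the scatter). All three values lie within the scatter of one another, so none of the three compounds can be set apart from the others.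

Compound 4 `CCOC(=O)Nc1cc(=O)oc2cc(OCc3cccc(Cl)c3)ccc12` is the next to be measured. It differs from compound 3 in one place: (ethoxycarbonyl)amino in place of phenoxy on an aromatic carbon. For the measured compounds named here, no measured step removes the phenoxy group itself; the two steps that touch this part of the core, no change at the digits printed from compound 1 to compound 3 (within the scatter) and a number 9 percentage points lower from compound 2 to compound 3 (within the scatter), exchange what hangs on the ring oxygen and leave the read-out essentially unmoved. The exchange in compound 4 is therefore an untested one, and with every measured value near the floor there is no basis to expect a step beyond the scatter in either direction. Compound 4 is expected to give 4%, within 0% to 18%, an estimated step of a number 4 percentage points higher from compound 3 to compound 4 (within the scatter).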

Compound 4, a percentage reported as inhibition, at one concentration (the size of the read-out at that concentration, not a potency): 21%
The estimate for compound 4 lay 17 percentage points below the measured number, and the stated range ends below it.
By their numbers in this assay, from the lowest: compounds 1, 3 and 2 (each within the scatter of the next); then compound 4.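

For the compounds shown here, at the aromatic carbon opposite the ring oxygen, the exchange of phenoxy for (ethoxycarbonyl)amino gives the first step in this assay that lies beyond the scatter, a number 21 percentage points higher from compound 3 to compound 4 (beyond the scatter), whereas the earlier steps among compound 1, compound 2 and compound 3 all stayed within it. The same separation appears when (ethoxycarbonyl)amino replaces (ethoxycarbonyl)methoxy, a number 21 percentage points higher from compound 1 to compound 4 (beyond the scatter), and when it replaces ((piperidin-1-yl)carbonyl)methoxy, a number 12 percentage points higher from compound 2 to compound 4 (beyond the scatter), so the three groups attached through oxygen at this carbon all stand apart from the one attached through nitrogen, though only by modest steps. No measurement available here bears on what lies behind this rise.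

The compounds shown do not separate the nitrogen link from the rest of the (ethoxycarbonyl)amino group, so it remains open whether a plain amine or an acetylamino group on this carbon would read with compound 4 or with compound 3, and whether a longer chain in place of the ethyl would hold the gain. As far as these compounds go, with a read-out at one concentration only, the potency of compound 4 also remains open.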